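Diaryl urea series: dropping the chlorine on the distal aryl

A few compounds are considered here, and "the series" means these few. Any claim that something is new, unique, unknown or untested is made for them only; others in the source may bear on it.

Compound 1 `O=C(Nc1ccc(-n2ncc3c(C(F)(F)F)cccc32)cc1)Nc1ccc(Cl)c(C(F)(F)F)c1` stands where only a limit is known: in a functional assay on SGC-7901 cells (Homo sapiens) for cytotoxicity, read by MTT assay, with a stated time of 72 h (on this read-out lower numbers stand for stronger inhibition and higher numbers for weaker inhibition), compound 1 gives > 32000 nM, which is a limit of the assay and not a number. Compound 2 `O=C(Nc1ccc(-n2ncc3c(Br)cccc32)cc1)Nc1ccc(Cl)c(C(F)(F)F)c1` gives 16600 nM in this assay. Among the measured compounds shown here, the single measured step, an at least 1.9-fold lower number from compound 1 to compound 2 (0.28 log units; that floor lies within the scatter), concerns bromo in place of trifluoromethyl on the other aryl. That step starts from the limit (the limit of > 32000 nM in this assay, at which 1 of the 2 values shown sits), so its true size is open. Compound 3 `O=C(Nc1ccc(-n2ncc3c(C(F)(F)F)cccc32)cc1)Nc1ccc(C(F)(F)F)cc1` differs from compound 1 by 4-(trifluoromethyl)phenyl in place of 4-chloro-3-(trifluoromethyl)phenyl on an amide-type nitrogen. For the measured compounds named here, no measured step touches this position, so the step from compound 1 to compound 2 gives no direct guide, and no step beyond the scatter is expected in this assay; a limit may well be returned again. Compound 3 is therefore expected near 40000 nM, between 15000 nM and 120000 nM. The implied step, a step that the limit leaves unreadable from compound 1 to compound 3, is an expectation only.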

Compound 3, half-maximal inhibitory concentration: 4000 nM
The estimate for compound 3 lay 10-fold (1.00 log units) above the measured number; the whole stated range lies above it.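

In this assay, 4-(trifluoromethyl)phenyl in place of 4-chloro-3-(trifluoromethyl)phenyl on an amide-type nitrogen gives an at least 8.0-fold lower number from compound 1 to compound 3 (0.90 log units; beyond the scatter). Among the compounds shown here, this is the first read on this position, and it shows that losing the chlorine from this aryl, with the core of compound 1 unchanged, moves the number by more than the scatter, whereas the floor of the earlier bromo step stayed within it. Only the floor of the new step can be read, since compound 1 sits at a limit: the limit of > 32000 nM in this assay, at which 1 of the 3 values shown sits.

Going by these compounds, whether the same change carries over to the bromo-bearing core of compound 2 remains open. Also open, on these data alone, is how this assay responds when the trifluoromethyl of the 4-(trifluoromethyl)phenyl group gives way to an amine, a methoxy or a nitrile.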